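Benzyl for fluorophenyl on the pyrazole nitrogen of compound 2

The source may report more compounds than this note shows. Statements on the series, on what has been measured and on what is new or still open speak of the compounds shown alone.

Measured so far:
compound 1 `Nc1cc(Cc2ccn(Cc3cccc(-c4ccccc4)c3)n2)c2nn[nH]c2n1` 1100 nM
compound 2 `Nc1cc(Cc2ccn(-c3ccc(F)cc3)n2)c2nn[nH]c2n1` 700 nM
compound 3 `Nc1cc(Cc2ccn(Cc3ccc4cnccc4c3)n2)c2nn[nH]c2n1` 1800 nM

In an assay on cells for inhibition of thyroid peroxidase (Homo sapiens), with stated times of 10 min and 15 min (a lower number here means a stronger inhibitor, a higher number a weaker inhibitor), compound 2 gives 700 nM, the low end of the three numbers. Compound 1 lies within the scatter of compound 2, while compound 3 stands beyond it. Compound 4 `Nc1cc(Cc2ccn(Cc3ccccc3)n2)c2nn[nH]c2n1` has not been measured. It differs from compound 2 in one place: benzyl in place of 4-fluorophenyl on an aromatic nitrogen. Within the data shown here, no step between measured compounds covers this exchange. Compound 1, which also carries a benzyl-type group, gives 1100 nM, and compound 3, which does too, gives 1800 nM. On that basis compound 4 is expected to land a little higher than compound 2, with the step from a 1.4-fold higher number from compound 2 to compound 4 (0.15 log units; within the scatter) most likely within the scatter. The estimate for compound 4 in this assay is 1000 nM, within 400 nM to 2500 nM.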

Compound 4, half-maximal inhibitory concentration: 2300 nM
For compound 4 the middle estimate is 2.3-fold (0.36 log units) below the measured one; low and high end bracket the measured number.
By their numbers in this assay, from the lowest: compounds 2, 1, 3 and 4 (each within the scatter of the next, the first and the last beyond it).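

In this assay benzyl in place of 4-fluorophenyl on the aromatic nitrogen gives a 3.3-fold higher number from compound 2 to compound 4 (0.52 log units; beyond the scatter) and so shows that the two groups are not interchangeable here, although each has one carbon-only aromatic ring. Hydrogen in place of phenyl on an aromatic carbon gives a 2.1-fold higher number from compound 1 to compound 4 (0.32 log units; beyond the scatter) as a second step, showing that the outer phenyl of compound 1 also counts in this assay. No available evidence accounts for either step. Still open, from the compounds shown here alone, is how a plain phenyl without fluorine on that nitrogen would compare with compound 2 and compound 4. Also open, going by these compounds, is what an amine or a carboxylic acid on the benzyl ring would do.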